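The source may hold more compounds than are shown below. What is called first, only, known or untested is meant among the compounds shown, and "the series" means these compounds.

Among the compounds with values here, in a functional assay on MCF7 cells (Homo sapiens) for cytotoxicity, read by MTT assay, with a stated time of 72 h (on this read-out higher numbers stand for weaker inhibition and lower numbers for stronger inhibition), compound 2 (`COc1ccc(/C=C2\CCC/C(=C\c3cccc(OC)c3OC)C2=O)cc1`) gives 18600 nM and stands highest of the two numbers so far, while compound 1 (`COc1cccc(/C=C2\CCC/C(=C\c3cccc(OC)c3OC)C2=O)c1`) gives 5900 nM on the same read-out. The next compound, compound 3 (`COc1cccc(/C=C2\CCC/C(=C\c3cccc(O)c3)C2=O)c1OC`), carries 3-hydroxyphenyl in place of 4-methoxyphenyl on a double-bonded chain carbon bound to a double-bonded ring carbon. Within the data shown here, the one measured step bearing on this change, with 4-methoxyphenyl entering in place of 3-methoxyphenyl at that place, is a 3.2-fold higher number from compound 1 to compound 2 (0.50 log units; beyond the scatter) and it counts as modest. Among the measured compounds shown here, no measured compound carries 3-hydroxyphenyl, so this evidence is indirect. Leaving 4-methoxyphenyl reversed that step, so a modest move toward a lower number is expected in this assay, and the estimated step is a 2.9-fold lower number from compound 2 to compound 3 (0.46 log units; beyond the scatter) in this case. Compound 3 is estimated at 6500 nM with an expected range (2200 nM to 18000 nM).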

Compound 3, half-maximal inhibitory concentration: 8800 nM
The estimate for compound 3 lay 1.4-fold (0.13 log units) below the measured number; measured number inside the range.
By their numbers in this assay, from the lowest: compounds 1 and 3 (each within the scatter of the next); then compound 2.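

In this assay, within the data shown here, the change at the place on a double-bonded chain carbon bound to a double-bonded ring carbon gives a 2.1-fold lower number from compound 2 to compound 3 (0.33 log units; beyond the scatter), and this is the first measured step to bring in a hydrogen-bond donor there. Hydrogen in place of methyl on the oxygen on the aromatic ring gives a 1.5-fold higher number from compound 1 to compound 3 (0.17 log units; within the scatter), so 3-hydroxyphenyl and 3-methoxyphenyl cannot be told apart on this read-out, while 4-methoxyphenyl in compound 2 stays apart from both. Nothing at hand accounts for these differences. From the compounds shown here alone, whether a 4-hydroxyphenyl group would stand with compound 2 or with compound 3 remains open. So does how an amine or a carboxylic acid on that phenyl ring would compare.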